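Replacing 2,4-difluorophenyl with butyl on a sulfonyl sulfur

The compounds below may be only part of what the source reports. "The series", "measured", "known", "first", "only" and "open" are said of these compounds alone.

Measured in a functional assay on SNU-638 cells (Homo sapiens) for antiproliferative activity, read by sulforhodamine B assay, with a stated time of 72 h; on this read-out lower numbers stand for stronger inhibition and higher numbers for weaker inhibition:
Compound 1 `CCOC(=O)c1cnc2ccc(-c3cnc(OC)c(NS(=O)(=O)c4ccc(F)cc4F)c3)cn12`: 360 nM
Compound 2 `CCOC(=O)c1cn2cc(-c3cnc(OC)c(NS(=O)(=O)c4ccc(F)cc4)c3)ccc2n1`: > 20000 nM (a limit)
Compound 3 `CCOC(=O)c1cc2cc(-c3cnc(OC)c(NS(=O)(=O)c4ccc(F)cc4)c3)ccc2[nH]1`: 15900 nM

Of the two true numbers in this assay, compound 1 holds the lower at 360 nM. Compound 3 stands higher at 15900 nM, and this gap lies beyond the scatter. Compound 2 reads > 20000 nM, which is a limit of the assay and not a number.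

The next compound to be tested is compound 4 `CCCCS(=O)(=O)Nc1cc(-c2ccc3ncc(C(=O)OCC)n3c2)cnc1OC`. It differs from compound 1 at one place, with butyl in place of 2,4-difluorophenyl on a sulfonyl sulfur. For the measured compounds named here, no measured pair isolates this change, so any forecast is uncertain. Going by the values given here, the expectation rests on compound 1, which at 360 nM has the lowest number so far, leaving a move towards weaker inhibition as the likelier outcome. In this assay the expected change is a 6.9-fold higher number from compound 1 to compound 4 (0.84 log units; beyond the scatter), a rise beyond the scatter. For compound 4 the estimated value is 2500 nM, with an expected range from 500 nM to 14000 nM.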

Compound 4, half-maximal inhibitory concentration: 510 nM
For compound 4 the middle estimate is 4.9-fold (0.69 log units) above the measured one; the measured number falls inside the stated range.
By their numbers in this assay, from the lowest: compounds 1 and 4 (each within the scatter of the next); then compound 3. At a limit, above all of these: compound 2.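

In this assay, for the compounds shown here, putting butyl in place of 2,4-difluorophenyl on a sulfonyl sulfur gives a 1.4-fold higher number from compound 1 to compound 4 (0.15 log units; within the scatter), and this is the first measured pair to isolate a change at this place. For this pair, the six-membered aromatic ring and both fluorine atoms can leave the sulfonyl sulfur, and an open chain with fewer heavy atoms can enter, without a change beyond the scatter, so that ring is not needed there to keep compound 4 within the scatter of compound 1. Nothing measured here accounts for this tolerance.

Going by these compounds, whether a shorter chain such as methyl, a longer chain such as octyl, or a ring such as cyclopropyl on the sulfonyl sulfur would stay within the scatter of compound 1 remains open. Compounds 2 and 3 differ from compound 1 in more than one place, so they do not bear on this change, and whether butyl would be tolerated on their cores is also unanswered.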